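A methoxy swap after two limit readings

The source may report more compounds than this note shows. Statements on the series, on what has been measured and on what is new or still open speak of the compounds shown alone.

Compound 1 `COc1cc(OC)c(OC)cc1/C=C/COC(=O)/C=C/c1cc(OC)c(OC)c(OC)c1OC`: > 200 mg/kg, a limit
Compound 2 `COc1cc(OC)c(OC)cc1/C=C/COC(=O)/C=C/c1ccccc1C(F)(F)F`: > 300 mg/kg, a limit

Both readings come from a functional assay on the whole organism (strain Kunming) with Mus musculus as the target, with a stated time of 0.5 h; on this read-out lower numbers stand for an effect already at smaller amounts and higher numbers for an effect only at larger amounts of compound. In this assay, compound 2 stands at > 300 mg/kg, which is a limit and not a number. Compound 1 also gives only a limit, > 200 mg/kg. For the measured compounds named here, the two compounds therefore offer no measured step to learn from.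

Compound 3 `COc1ccc(/C=C/C(=O)OC/C=C/c2cc(OC)c(OC)cc2OC)cc1` differs from compound 2 in one place: 4-methoxyphenyl in place of 2-(trifluoromethyl)phenyl on a double-bonded chain carbon bound to a double-bonded chain carbon. The 4-methoxyphenyl takes the place of the 2-(trifluoromethyl)phenyl on a double-bonded chain carbon bound to a double-bonded chain carbon. With nothing firmer to go on, no clear change is expected, and a further limit reading would be no surprise. The expected size of the step of an at least 1.2-fold lower number from compound 2 to compound 3 (0.07 log units; that floor lies within the scatter) is estimated to stay within the usual scatter. For compound 3, the estimated value is 250 mg/kg, with an expected range from 100 mg/kg to 500 mg/kg.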

Compound 3, dose for half-maximal effect: > 300 mg/kg
Compound 3 ended at the assay's limit; the forecaster's own chance of this, stated with the estimate: 60%; at least 1.2-fold (0.07 log units) between middle value and limit.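

For the compounds shown here, compound 2 and compound 3 both give only a limit, not a number, so no step between them can be read. The compounds shown leave open whether 4-methoxyphenyl in place of 2-(trifluoromethyl)phenyl changes the effective dose at all, and what dose any of these compounds would need.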